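A few compounds are considered here, and "the series" means these few. Any claim that something is new, unique, unknown or untested is made for them only; others in the source may bear on it.

Measured so far:
- compound 1 `COc1cccc(C(O)CCn2nc3c(Br)c(Br)c(Br)c(Br)c3n2)c1`: 48%
- compound 2 `C[C@H](O)CCn1nc2c(Br)c(Br)c(Br)c(Br)c2n1`: 36%

In a functional assay on CCRF-CEM cells (Homo sapiens) for antiproliferative activity, read by MTT assay, with a stated time of 24 h, tested at 100 uM (on this read-out higher numbers stand for a weaker effect at the one concentration tested and lower numbers for a stronger effect), compound 1 gives 48%, the higher of the two numbers recorded, that is the weaker effect at the one concentration tested. The nearest neighbour is compound 2, which in this assay gives 36%, a number lower than compound 1 by a gap that goes beyond the usual scatter. For the measured compounds named here, the two compounds differ in more than one place, so no single structural step can be read from this pair, and no step between measured compounds is available for the series.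

Compound 3 `OC(CCn1nc2c(Br)c(Br)c(Br)c(Br)c2n1)c1ccc(Br)cc1` differs from compound 1 in one place: 4-bromophenyl in place of 3-methoxyphenyl on a saturated chain carbon bound to an oxygen on a saturated carbon and a saturated chain carbon

Going by the values given here, no measured pair shows an exchange of one aryl group for another at this position, so the direction of the step cannot be taken from the data. In this assay the step from compound 1 to compound 3 is expected to be small, not clearly beyond the scatter, with no preferred direction.

Compound 3 is expected in this assay at 44%, within a range from 26% to 62%. This estimate means a step of a number 4 percentage points lower from compound 1 to compound 3 (within the scatter) in this assay.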

Compound 3, a percentage reported as activity, at one concentration (the size of the read-out at that concentration, not a potency): 0%
Compound 3: the middle estimate sits 44 percentage points above what was measured; the whole stated range lies above it.
By their numbers in this assay, from the lowest: compound 3; then compound 2; then compound 1.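

In this assay, for the compounds shown here, the aryl group on the saturated chain carbon bound to an oxygen matters strongly: 4-bromophenyl in place of 3-methoxyphenyl gives a number 48 percentage points lower from compound 1 to compound 3 (beyond the scatter) and so a stronger effect at the one concentration tested, in the first single-place step. With compound 3 at 0% and no other step for comparison, this position is shown to be one where exchanging one substituted phenyl for another can move the number far beyond the scatter. Nothing on hand explains the size of this step.

The step changes the substituent and its place on the ring together, so 3-bromophenyl and 4-methoxyphenyl would be needed to tell these two changes apart, and an unsubstituted phenyl would give a reference for both. As far as these compounds go, the potency of compound 3 also stays open, as does whether a single step at this position holds for other groups such as an aminophenyl, since this assay gives the size of the read-out at one concentration only.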